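The source may hold more compounds than are shown below. What is called first, only, known or untested is meant among the compounds shown, and "the series" means these compounds.

Measured compounds:
compound 1, `CSc1cccc(CSc2nc(-c3ccc(F)cc3)c(-c3ccncc3)[nH]2)c1`: 550 nM
compound 2, `Fc1ccc(-c2[nH]c(SCC3CCCCC3)nc2-c2ccncc2)cc1`: 240 nM

In a functional assay (Homo sapiens) for inhibition (a higher number here means a weaker inhibitor, a lower number a stronger inhibitor), compound 1 gives the higher of the two numbers. Compound 2 gives 240 nM, and the gap between the two lies beyond the usual scatter, so compound 1 is the weaker inhibitor of this pair. Going by the values given here, no single-change step between measured compounds is available.

Compound 3, `CSc1cc(Cl)cc(CSc2nc(-c3ccc(F)cc3)c(-c3ccncc3)[nH]2)c1O`, keeps the shared core of compound 1 and changes only the aryl group on the saturated chain carbon bound to a sulfur: 5-chloro-2-hydroxy-3-(methylsulfanyl)phenyl in place of 3-(methylsulfanyl)phenyl on a saturated chain carbon bound to a sulfur.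

Among the compounds with values here, with no measured step of this type to lean on, a step near zero in this assay is expected, with the scatter allowing either direction. Compound 3 is therefore estimated at 450 nM, within a range from 150 nM to 1400 nM, which corresponds to an expected step of a 1.2-fold lower number from compound 1 to compound 3 (0.09 log units; within the scatter).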

Compound 3, half-maximal inhibitory concentration: 640 nM
Compound 3: the middle estimate sits 1.4-fold (0.15 log units) below what was measured; the measured number falls inside the stated range.
By their numbers in this assay, from the lowest: compound 2; then compounds 1 and 3 (each within the scatter of the next).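

In this assay, 5-chloro-2-hydroxy-3-(methylsulfanyl)phenyl in place of 3-(methylsulfanyl)phenyl on a saturated chain carbon bound to a sulfur gives a 1.2-fold higher number from compound 1 to compound 3 (0.07 log units; within the scatter). This place therefore takes the larger aryl group, with its added chlorine and hydroxyl and its extra hydrogen-bond donor and acceptor, without a difference that can be read in this series. No measured property bears on this result, so the reading stops at the numbers.

On these data alone, the chlorine and the hydroxyl enter together, so what each does alone stays open, and two opposing contributions cannot be told apart from no contribution. Also open, as far as these compounds go, is whether an amine or a carboxylic acid on this aryl group would move the number beyond the scatter.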